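This account rests on a few compounds, and the source may have more. Where it says the series, first, only, none or still open, it means among the compounds named here.

Measured so far in a functional assay on BXPC-3 cells (Homo sapiens) for inhibition, read by MTT assay, with a stated time of 7 days; on this read-out higher numbers stand for weaker inhibition and lower numbers for stronger inhibition:
Compound 1 `O=C([C@@H]1CCCN(S(=O)(=O)c2ccc(S(=O)(=O)N3CC[C@H](O)C3)cc2)C1)N1CCC(F)(F)CC1` gives 580 nM.
Compound 2 `CCN(CC)S(=O)(=O)c1ccc(S(=O)(=O)N2CCC[C@@H](C(=O)N3CCOCC3)C2)cc1` gives 790 nM.
Compound 3 `CCN(CC)S(=O)(=O)c1ccc(S(=O)(=O)N2CCC[C@@H](C(=O)N3CC[C@@H](OC)C3)C2)cc1` gives 11500 nM.

Compound 1 has the lowest number of the three; compound 2 sits within the scatter of it, so no order between those two can be claimed, while compound 3 lies well beyond the scatter above both. Within the data shown here, the one step between compounds that differ in a single place, a 15-fold higher number from compound 2 to compound 3 (1.16 log units; beyond the scatter), concerns a change on a carbonyl carbon.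

Compound 4 `O=C([C@@H]1CCCN(S(=O)(=O)c2ccc(S(=O)(=O)C3CC3)cc2)C1)N1CCC(F)(F)CC1` differs from compound 1 in another place: cyclopropyl in place of 3-hydroxypyrrolidin-1-yl on a sulfonyl sulfur. Among the measured compounds shown here, no measured step touches the group on the sulfonyl sulfur, so the single step in hand cannot guide this change, and the expectation rests only on the fact that compound 1 is the strongest reference available and that many changes elsewhere in this set have cost potency. The number for compound 4 is therefore expected to rise somewhat, a step of a 2.1-fold higher number from compound 1 to compound 4 (0.32 log units; beyond the scatter). The estimate for compound 4 is 1200 nM, with a range from 350 nM to 4500 nM.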

Compound 4, half-maximal inhibitory concentration: 129 nM
For compound 4 the middle estimate is 9.3-fold (0.97 log units) above the measured one; the measured number lies below the stated range.
By their numbers in this assay, from the lowest: compound 4; then compounds 1 and 2 (each within the scatter of the next); then compound 3.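

On the sulfonyl sulfur, the group can change considerably without any loss in this assay: cyclopropyl in place of 3-hydroxypyrrolidin-1-yl gives a 4.5-fold lower number from compound 1 to compound 4 (0.65 log units; beyond the scatter). This first measured step at this position shows that compound 1's 3-hydroxypyrrolidin-1-yl, with its hydrogen-bond donor, hydrogen-bond acceptor and defined stereocentre, is not required for activity here, since a smaller, carbon-only group with neither donor nor acceptor gives the lower number. Nothing available explains this drop.

Going by these compounds, it remains open whether the gain comes from cyclopropyl itself or simply from the loss of the hydroxypyrrolidine; a plain pyrrolidin-1-yl or a methyl on the same sulfonyl sulfur would help separate the two. On these data alone, it is also open whether cyclopropyl would give a similar step in compounds carrying the morpholin-4-yl amide of compound 2.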